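Swapping the aryl group on compound 2

The source may report more compounds than this note shows. Statements on the series, on what has been measured and on what is new or still open speak of the compounds shown alone.

The two measured compounds here, compound 1 `CC(C)n1ncc2c(C(=O)Nc3cccnc3)cccc21` and compound 2 `Cc1ccc(-n2cc(CNC(=O)c3cccc4c3cnn4C(C)C)nn2)cc1C`, share a core and differ in the amide partner. In a functional assay on MGC-803 cells (Homo sapiens) for inhibition, read by MTT assay, with a stated time of 72 h (on this read-out higher numbers stand for weaker inhibition and lower numbers for stronger inhibition), compound 1 gives > 40000 nM, which is a limit of the assay and not a number. In this assay compound 2 likewise gives > 40000 nM, again a limit rather than a measured number. Among the measured compounds shown here, compound 2 therefore stands at the limit itself, as does the one other value shown, so the limit of > 40000 nM in this assay, at which 2 of the 2 values shown sit, sums up the whole measured picture, and no step between measured compounds can be stated. Compound 3 `CC(C)n1ncc2c(C(=O)NCc3cn(-c4ccc(F)cc4)nn3)cccc21` is the unmeasured member; it differs from compound 2 by 4-fluorophenyl in place of 3,4-dimethylphenyl on an aromatic nitrogen. Because both measured compounds sit at the limit of > 40000 nM in this assay, at which 2 of the 2 values shown sit, no step beyond the scatter is expected in this assay, and the expected change a number no higher from compound 2 to compound 3 (the limit leaves the size open) is essentially none. Compound 3 is estimated to give 40000 nM in this assay, within 15000 nM to 100000 nM, most likely reported again only as a limit.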

Compound 3, half-maximal inhibitory concentration: > 40000 nM
Compound 3 ended at the assay's limit; the forecaster's own chance of this, stated with the estimate: 80%; the middle value sits exactly at the limit.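

In this assay compound 3 gives > 40000 nM, which is a limit of the assay and not a number. Compound 2 also stands at a limit, so no step can be read between compound 2 and compound 3. The compounds shown leave open which structural change, if any, would bring a measurable value in this assay.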